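This account rests on a few compounds, and the source may have more. Where it says the series, first, only, none or still open, it means among the compounds named here.

Measured compounds:
compound 1 `CC(=O)OC/C(=C\c1ccc([N+](=O)[O-])cc1)C(=O)c1ccccc1` gives 23000 nM in a functional assay on WiDr cells (Homo sapiens) for inhibition, read by sulforhodamine B assay, with a stated time of 48 h; a higher number here means a weaker inhibitor of growth, a lower number a stronger inhibitor of growth
compound 2 `CC(=O)OC/C(=C\c1ccc(Cl)cc1)C(=O)c1ccc(Cl)cc1` gives 18000 nM in this assay
compound 3 `C=C(C/C(=C\c1ccc(Cl)cc1)C(=O)c1ccccc1)C(=O)c1ccccc1` gives 20000 nM in this assay

All three compounds are weak inhibitors of growth in this assay. Compound 3 sits in the middle of the three numbers, with compound 2 nearest and compound 1 furthest from it, and both gaps lie within the usual scatter of repeated measurements, so the three cannot be told apart on these data.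

Compound 4 `C=C(C/C(=C\c1ccc(OC)cc1)C(=O)c1ccccc1)C(=O)c1ccccc1` differs from compound 3 in one place: methoxy in place of chloro on an aromatic carbon. Within the data shown here, no pair of measured compounds shows what this change does, and the three measured numbers give no hint that a change on this ring shifts the result much. The step from compound 3 to compound 4 in this assay is therefore expected to be small, in neither direction beyond the scatter, which is the meaning of no change at the digits printed from compound 3 to compound 4 (within the scatter).

Compound 4 is estimated at 20000 nM, with a range from 8000 nM to 50000 nM.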

Compound 4, concentration for 50% growth inhibition: 470 nM
Compound 4: the middle estimate sits 43-fold (1.63 log units) above what was measured; measured number below the stated range.
By their numbers in this assay, from the lowest: compound 4; then compounds 2, 3 and 1 (each within the scatter of the next).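

In this assay, replacing the 4-chlorophenyl group with 4-methoxyphenyl gives a 43-fold lower number from compound 3 to compound 4 (1.63 log units; beyond the scatter), a change at one ring position, para to a large group. Among these compounds, the three earlier compounds contained no pair differing in one place, so they could not show that this single swap can move the result so far. No measurement here speaks to the reason for this step.

Going by these compounds, it remains open whether this result is particular to methoxy, or whether a hydroxy group, an ethoxy group or a dimethylamino group at the same position would give a similar number. Also open, on these data alone, is whether methoxy in place of chloro would have a similar effect on the core of compound 2, which carries an acetate side chain rather than the second phenyl ketone of compound 3.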